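The source may report more compounds than this note shows. Statements on the series, on what has been measured and on what is new or still open speak of the compounds shown alone.

Measured in a functional assay on A549 cells (Homo sapiens) for inhibition, read by CCK-8 assay, with a stated time of 48 h; on this read-out lower numbers stand for stronger inhibition and higher numbers for weaker inhibition:
- compound 1 `COc1cc(-c2ccnc3cc(-c4ccc(F)cc4)nn23)cc(OC)c1OC`: 3800 nM
- compound 2 `COc1cc(-c2ccnc3cc(-c4ccc5cc[nH]c5c4)nn23)cc(OC)c1OC`: 170 nM
- compound 3 `COc1cc(-c2ccnc3cc(-c4ccc(N(C)C)cc4)nn23)cc(OC)c1OC`: 1100 nM

Compound 3 sits in the middle of these three numbers: a 3.5-fold lower number from compound 1 to compound 3 (0.54 log units; beyond the scatter), and a 6.5-fold higher number from compound 2 to compound 3 (0.81 log units; beyond the scatter). Compound 4 `COc1ccc(-c2cc3nccc(-c4cc(OC)c(OC)c(OC)c4)n3n2)cc1N` keeps the shared core and changes one group: 3-amino-4-methoxyphenyl in place of 4-(dimethylamino)phenyl on an aromatic carbon. Within the data shown here, no measured step makes this exact swap. The nearest guides are changes at the same place, above all a 22-fold lower number from compound 1 to compound 2 (1.35 log units; beyond the scatter), a large step, and the two modest steps already given. They show that this group can move the number strongly, and compound 2 at 170 nM shows how far down it has gone so far. A modest fall is therefore expected, though with real uncertainty. The expected change is a 5.5-fold lower number from compound 3 to compound 4 (0.74 log units; beyond the scatter). For compound 4 the estimated value is 200 nM, with an expected range of 40 nM to 1000 nM.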

Compound 4, half-maximal inhibitory concentration: 138 nM
Beside the measured number, compound 4's estimate is 1.4-fold (0.16 log units) above it, within the range that was stated.
By their numbers in this assay, from the lowest: compounds 4 and 2 (each within the scatter of the next); then compound 3; then compound 1.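

In this assay, compound 4 shows that a low number at this position does not need the two-ring 1H-indol-6-yl group of compound 2: 3-amino-4-methoxyphenyl, with one six-membered aromatic ring of carbon only, lies within the scatter of it (a 1.2-fold lower number from compound 2 to compound 4 (0.09 log units; within the scatter)). The same group clearly improves on 4-(dimethylamino)phenyl (an 8.0-fold lower number from compound 3 to compound 4 (0.90 log units; beyond the scatter)) and 4-fluorophenyl (a 28-fold lower number from compound 1 to compound 4 (1.44 log units; beyond the scatter)). Since 4-(dimethylamino)phenyl and 3-amino-4-methoxyphenyl have equal heavy-atom counts, that count alone does not set the number.

Going by these compounds, whether the amine or the methoxy group matters more remains open, and a 3-aminophenyl or a 4-methoxyphenyl group would separate them. No measurement shown here explains these differences.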